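Extending the amino group of compound 3

The source may report more compounds than this note shows. Statements on the series, on what has been measured and on what is new or still open speak of the compounds shown alone.

In an ADME assay on a cell-free system (serum) for metabolic stability (on this read-out lower numbers stand for a shorter-lived compound and higher numbers for a longer-lived compound), compound 1 `CC(C)(C)c1cc(OC(=O)c2ccc(N)cc2)ccc1O` gives < 0.25 h as a limit of the assay and not a number. Compound 2 `CC(C)(C)c1cc(NC(=O)c2ccc(Cl)cc2Cl)ccc1O` gives > 1 h as a limit too. Compound 3 `CC(C)(C)c1cc(NC(=O)c2c(Cl)cc(N)cc2Cl)ccc1O` gives > 1 h as a limit as well, the same one as compound 2, so it has no exact value. Compound 4 `CC(C)(C)c1cc(NC(=O)c2c(Cl)cc(NCc3ccncc3)cc2Cl)ccc1O` differs from compound 3 by (pyridin-4-yl)methyl in place of hydrogen on a nitrogen on an aromatic ring. Among the measured compounds shown here, no measured pair shows this change, so in this assay no step beyond the usual scatter is expected. The estimated change is small (a step that the limit leaves unreadable from compound 3 to compound 4). Compound 4 is expected at an estimated 1.5 h (range 0.7 h to 4 h).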

Compound 4, half-life: > 1 h
Compound 4: a limit, no number; the forecaster's own chance of this, stated with the estimate: 65%; the middle value is on the limit's open side.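

Compound 3 and compound 4 both stop at the same limit of this assay, so no step between them can be read: the limit of > 1 h in this assay, at which 3 of the 4 values shown sit.

From the compounds shown here alone, how long each actually lasts, and whether the (pyridin-4-yl)methyl changes that at all, stays open.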